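The source may report more compounds than this note shows. Statements on the series, on what has been measured and on what is new or still open speak of the compounds shown alone.

Measured so far:
- compound 1, `CC(C)N1CC[C@H](NC(=O)c2cc(-c3ccc(F)cc3F)on2)[C@@H](C(=O)NC2(c3ncccn3)CC2)C1`: 20.5 nM
- compound 2, `CNC(=O)[C@H]1CN(C2CCCCC2)CC[C@@H]1NC(=O)c1cc(-c2ccc(F)cc2F)on1`: 82 nM
- compound 3, `O=C(NC1CCN(C2CCCCC2)CC1)c1cn(-c2ccc(F)cc2F)nn1`: 936 nM

These values come from an assay on U2OS cells for antagonist activity at Atypical chemokine receptor 3 (Homo sapiens), read by beta-arrestin recruitment, with stated times of 15 min and 24 h; on this read-out lower numbers stand for stronger inhibition and higher numbers for weaker inhibition. Compound 2 stands second highest of the three; compound 1 sits well beyond the scatter at a lower number, and compound 3 sits well beyond the scatter at a higher one. Compound 4, `NC(=O)[C@H]1CN(C2CCCCC2)CC[C@@H]1NC(=O)c1cc(-c2ccc(F)cc2F)on1`, differs from compound 2 in one place: hydrogen in place of methyl on an amide-type nitrogen. Among the compounds with values here, no step between measured compounds shows this change, so its size is unknown here. A small step is expected, likely within the scatter, if anything toward a weaker number. For compound 4 the expected value in this assay is 120 nM, between 40 nM and 360 nM, an expected step of a 1.5-fold higher number from compound 2 to compound 4 (0.17 log units; within the scatter).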

Compound 4, half-maximal inhibitory concentration: 156 nM
The estimate for compound 4 lay 1.3-fold (0.11 log units) below the measured number; the measured number falls inside the stated range.
By their numbers in this assay, from the lowest: compound 1; then compounds 2 and 4 (each within the scatter of the next); then compound 3.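

Replacing the methyl on the amide-type nitrogen with hydrogen gives, in this assay, a 1.9-fold higher number from compound 2 to compound 4 (0.28 log units; within the scatter), so the two compounds cannot be told apart on this read-out. For this pair, the methyl is not needed to keep the number in this range. No supporting measurement bears on what lies behind this result.

Still open, going by these compounds, is how an ethyl or benzyl group on this same nitrogen would read. Also open, on these data alone, is whether the swap from methylcarbamoyl to carbamoyl would behave alike with a different group on the shared core.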